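Swapping fluoro for methoxy on a weak pancreatic cell inhibitor

The source may hold more compounds than are shown below. What is called first, only, known or untested is meant among the compounds shown, and "the series" means these compounds.

The series is small. Compound 1 `COc1ccc2c(/C=C(\C#N)C(=O)c3c[nH]c4cc(F)ccc34)c[nH]c2c1` sits at a limit in a functional assay on MIA PaCa-2 cells (Homo sapiens) for cytotoxicity, read by WST assay, with a stated time of 48 h; on this read-out lower numbers stand for stronger inhibition and higher numbers for weaker inhibition: for compound 1 the assay reports only > 50000 nM, a limit rather than a number, and the limit of > 50000 nM in this assay, at which 1 of the 2 values shown sits, shows this. Compound 2 `N#C/C(=C\c1c[nH]c2cc(F)ccc12)C(=O)c1c[nH]c2ccccc12` is the only compound in the set for which a number is shown: in this assay compound 2 gives 31600 nM, so the pair offers one weak value and no measured step to lean on.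

Compound 3 `COc1ccc2c(/C=C(\C#N)C(=O)c3c[nH]c4ccccc34)c[nH]c2c1` has not yet been measured. It differs from compound 2 by methoxy in place of fluoro on an aromatic carbon.

With no measured step between these compounds, the expectation for the change from compound 2 to compound 3 in this assay is a step of modest size, if any, most likely toward weaker inhibition, since the one number shown already lies close to the limit reached by compound 1. Compound 3 is therefore expected to give about 40000 nM, within 15000 nM to 110000 nM, a step of a 1.3-fold higher number from compound 2 to compound 3 (0.10 log units; within the scatter) that is itself an estimate and may well end as a limit rather than a number.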

Compound 3, half-maximal inhibitory concentration: > 50000 nM
Compound 3 ended at the assay's limit; the forecaster's own chance of this, stated with the estimate: 45%; middle value at least 1.2-fold (0.09 log units) away from the limit.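

In this assay, for the compounds shown here, methoxy in place of fluoro on an aromatic carbon gives an at least 1.5-fold higher number from compound 2 to compound 3 (0.19 log units; that floor lies within the scatter), the first step at this position that can be read at all, although only its floor is known. With that floor inside the scatter, the step does not show that methoxy here is truly worse than fluoro, and the series now offers little room to tell such a change apart: the limit of > 50000 nM in this assay, at which 2 of the 3 values shown sit. The step for hydrogen in place of fluoro on an aromatic carbon joins two limits and cannot be read, so the compounds shown say nothing about how much either of those groups matters on its own.

Going by these compounds alone, what stays open is how far the true value of compound 3 lies from that of compound 2, since the one reading for compound 3 is a limit and not a number. Within the data shown here, also open is whether any other group on this aromatic carbon, such as an amine, a hydroxyl or a carboxylic acid, would give a clearly lower number in this assay than the one group so far tied to a measured number.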